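The compounds below may be only part of what the source reports. "The series", "measured", "known", "first", "only" and "open" are said of these compounds alone.

Measured so far in an ADME assay on microsomes from liver (Homo sapiens) for metabolic stability, read by LC-MS, with a stated time of 10 min; a lower number here means that less of the compound is left, a higher number that more of the compound is left:
- compound 1 `CN(C[C@H]1Cc2c(cccc2N2CCN3CCC[C@@H]3C2)CN1)[C@H]1CCCc2cccnc21`: 52.2%
- compound 2 `CN(C[C@H]1Cc2c(cccc2N2C[C@@H]3C[C@H]2CN3)CN1)[C@H]1CCCc2cccnc21`: 100%

Of these two compounds, compound 2 stands higher, at 100% in this assay. Among the compounds with values here, the single measured step between them is a number 47.8 percentage points higher from compound 1 to compound 2 (beyond the scatter). It replaced the whole group on an aromatic carbon, and it is large.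

The next compound, compound 3 `CN(C[C@H]1Cc2c(cccc2N2C[C@H]3C[C@@H]2CN3)CN1)[C@H]1CCCc2cccnc21`, is a subtler case: the two compounds have the same atoms and bonds and differ only in configuration as drawn: 2 of 4 stereo elements differ; a stereocentre at a saturated ring carbon is drawn S in compound 2 and R in compound 3; a stereocentre at a saturated ring carbon is drawn S in compound 2 and R in compound 3. Only the spatial arrangement at those two ring carbons changes. Within the data shown here, no measured pair tests a change of configuration alone, so the large step above bears on this one only loosely, as a sign that this part of the molecule can matter in this assay. Compound 2 also leaves no room for a rise on this scale, since its reading of 100% is already as high as this read-out normally goes. A small fall is therefore expected, much smaller than the measured step and possibly within the scatter. The estimated change is a number 10 percentage points lower from compound 2 to compound 3 (within the scatter). For compound 3 the expected value is 90%, with an estimated range from 68% to 100%.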

Compound 3, percent of the compound remaining: 100%
Compound 3: middle estimate off by 10 percentage points, on the low side; the measured number falls inside the stated range.
By their numbers in this assay, from the lowest: compound 1; then compounds 2 and 3 (each within the scatter of the next).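

In this assay, changing the configuration at the two saturated ring carbons gives no change at the digits printed from compound 2 to compound 3 (within the scatter), so this read-out registers no effect of the spatial arrangement at those carbons. The replacement on the aromatic carbon gives a number 47.8 percentage points higher from compound 1 to compound 3 (beyond the scatter), which shows that the large rise seen earlier is not tied to just one drawn form of the group of 7 heavy atoms. This pair is the only one shown that tests configuration by itself, and its reading rests on one fact: the fact that compounds 2 and 3 differ only in the configuration as drawn.

Compound 2 and compound 3 both sit as high as this read-out normally goes, so a difference between them that would appear only over a longer incubation stays hidden, and the result cannot be taken as proof that the two forms are equally stable. Going by these compounds, it also remains open whether the high reading requires a group with two rings at all, or whether a single morpholine ring on the same aromatic carbon would give a similar number.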